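From compound 3 to compound 4: one group exchanged

The source may report more compounds than this note shows. Statements on the series, on what has been measured and on what is new or still open speak of the compounds shown alone.

Three amides with a shared core carry entries in an ADME assay on microsomes from liver (Mus musculus) for metabolic stability, with a stated time of 10 min (on this read-out lower numbers stand for a less stable compound and higher numbers for a more stable compound), and frame this comparison. Compound 1 (`O=C(O)[C@H]1CC[C@](F)(C(=O)N2CC[C@](c3ccc(C(F)(C(F)(F)F)C(F)(F)F)cc3)(S(=O)(=O)c3ccc(F)cc3)C2)CC1`) has the entry "not determined" (no result reported) and so adds no number. Compound 2 (`C[C@]1(C(=O)N2CC[C@](c3ccc(C(F)(C(F)(F)F)C(F)(F)F)cc3)(S(=O)(=O)c3ccc(F)cc3)C2)CC[C@@H](C(=O)O)CC1`) gives 100% in this assay and compound 3 (`O=C(O)C12CCC(C(=O)N3CC[C@](c4ccc(C(F)(C(F)(F)F)C(F)(F)F)cc4)(S(=O)(=O)c4ccc(F)cc4)C3)(CC1)OC2`) gives 94% on the same read-out. Going by the values given here, compound 3 thus stands level with compound 2, the only other number available, and the gap between them (a number 6 percentage points lower from compound 2 to compound 3 (within the scatter)) does not separate them.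

Compound 4 (`O=C(C1CCS(=O)(=O)CC1)N1CC[C@](c2ccc(C(F)(C(F)(F)F)C(F)(F)F)cc2)(S(=O)(=O)c2ccc(F)cc2)C1`) has not yet been measured. The change (a group of 8 heavy atoms (5 carbon, 2 oxygen, 1 sulfur; one six-membered non-aromatic ring with 1 hetero atom) in place of a group of 11 heavy atoms (8 carbon, 3 oxygen; one six-membered non-aromatic ring of carbon only, one six-membered non-aromatic ring with 1 hetero atom), on a carbonyl carbon) brings in 1,1-dioxothian-4-yl on a carbonyl carbon whose other neighbours are: amide-type nitrogen in a ring.

Among the compounds with values here, only the step already given bears on this, since it is the one measured exchange on that carbonyl carbon, and it stayed within the scatter. Within the data shown here, it is thin guidance, as no measured compound carries the entering group, so the range must stay wide. No step beyond the scatter is expected here, and only a slight fall is estimated (a number 6 percentage points lower from compound 3 to compound 4 (within the scatter)) with real uncertainty on the low side. The estimate for compound 4 is 88% with 65% and 100% as its expected bounds.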

Compound 4, percent of the compound remaining: 96%
Estimate against measurement, compound 4: 8 percentage points below; measured number inside the range.
By their numbers in this assay, from the lowest: compounds 3, 4 and 2 (each within the scatter of the next).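

Until compound 4, every number on this carbonyl carbon came from a group carrying a carboxylic acid, so the measured compounds could not show whether this assay stays at this level without one. The 1,1-dioxothian-4-yl group, with its ring sulfur and no hydrogen-bond donor, answers this for the one case shown: the result is a number 2 percentage points higher from compound 3 to compound 4 (within the scatter) and a number 4 percentage points lower from compound 2 to compound 4 (within the scatter), so compound 4 stands level with both acid-bearing compounds and the exchange is not separated from the scatter. No measurement shown here offers an explanation for this outcome.

All three numbers lie close together. The compounds shown do not reveal which kind of group on this carbonyl carbon would bring a clear fall in the read-out, and whether a piperidine, a pyridine ring or an open alkyl chain would stand at the same level remains open. Compound 1 gives no number, so its fluorine-bearing cyclohexane acid cannot be set beside the others, and all of these comparisons rest on the one shared core.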